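This account rests on a few compounds, and the source may have more. Where it says the series, first, only, none or still open, it means among the compounds named here.

Compound 1 has the structure `O=C(COc1ccc(C(=O)/C=C/c2ccc(F)c(F)c2)cc1)N[C@H]1CCOC1=O`. For the measured compounds named here, in a functional assay on PC-3 cells (Homo sapiens) for antiproliferative activity, read by MTT assay, with a stated time of 72 h (on this read-out lower numbers stand for stronger inhibition and higher numbers for weaker inhibition), compound 1 gives 21900 nM, and this is the only actual number in the set, so compound 1 stands alone as the one point of reference. Compound 2, with the structure `Cc1cc(Cl)ccc1NCC(=O)N[C@H]1CCOC1=O`, returns in this assay only a limit, > 64000 nM, not a number. That limit, (the limit of > 64000 nM in this assay, at which 1 of the 2 values shown sits), marks the edge of what this assay reports. Compound 3, with the structure `O=C(COc1ccc(C(=O)/C=C/c2ccccc2Br)cc1)N[C@H]1CCOC1=O`, has not yet been measured; it differs from compound 1 by 2-bromophenyl in place of 3,4-difluorophenyl on a double-bonded chain carbon bound to a double-bonded chain carbon. Going by the values given here, no measured pair of compounds shares this change, so nothing in the data gives the size of its effect. The expected step is therefore small, a 1.0-fold higher number from compound 1 to compound 3 (0.00 log units; within the scatter), not beyond the ordinary scatter of repeated measurements. On that basis compound 3 is estimated at 22000 nM in this assay, with a plausible range from 8000 nM to 60000 nM.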

Compound 3, half-maximal inhibitory concentration: 3260 nM
Compound 3: the middle estimate sits 6.7-fold (0.83 log units) above what was measured; the whole stated range lies above it.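

Before this result, no measured pair showed how much the group at this place matters in this assay. Putting 2-bromophenyl in place of 3,4-difluorophenyl gives a 6.7-fold lower number from compound 1 to compound 3 (0.83 log units; beyond the scatter) and so shows that, with the rest of the molecule unchanged, the choice of aromatic group on this double-bonded chain carbon can shift the read-out beyond ordinary scatter. Nothing measured here explains why the number falls.

From the compounds shown here alone, this single swap removes two fluorines and adds one bromine, so it remains open whether the step comes from gaining the bromine, losing the fluorines, or both. Plain phenyl, chlorophenyl or methoxyphenyl at this place could help separate these possibilities, but the compounds shown include none of these groups.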